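The source may report more compounds than this note shows. Statements on the series, on what has been measured and on what is new or still open speak of the compounds shown alone.

Measured so far:
compound 1 `COc1ccc2[nH]c(C(=O)N3CC(=O)N(Cc4ccccc4)[C@@H](COCc4ccccc4)C3)cc2c1` — in a physicochemical assay for solubility, read by spectrophotometry, in phosphate buffer, with a stated time of 2 h, at pH 7.4 (on this read-out lower numbers stand for lower solubility and higher numbers for higher solubility), compound 1 gives 8800 nM
compound 2 `COc1ccc2[nH]c(C(=O)N3CC(=O)N(Cc4ccccc4)[C@@H](CN4CC5CC5C4)C3)cc2c1` — in this assay compound 2 gives 17500 nM

Compound 2 and compound 1 lie within the scatter of each other, as a 2.0-fold higher number from compound 1 to compound 2 (0.30 log units; within the scatter) shows. Compound 3 `COc1ccc2[nH]c(C(=O)N3CC(=O)N(Cc4ccccc4)[C@@H](CN4CCc5ccccc5C4)C3)cc2c1` differs from compound 2 by a group of 10 heavy atoms (9 carbon, 1 nitrogen; one six-membered non-aromatic ring with 1 hetero atom, one six-membered aromatic ring of carbon only) in place of a group of 6 heavy atoms (5 carbon, 1 nitrogen; one three-membered non-aromatic ring of carbon only, one five-membered non-aromatic ring with 1 hetero atom), on a saturated chain carbon bound to a saturated ring carbon. Within the data shown here, the only measured step at this place is a 2.0-fold higher number from compound 1 to compound 2 (0.30 log units; within the scatter), and it stayed within the scatter, so no step beyond the scatter is expected here either. Compound 3 is expected to give 11000 nM, in the range 3500 nM to 30000 nM. The expected step is a 1.6-fold lower number from compound 2 to compound 3 (0.20 log units; within the scatter).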

Compound 3, solubility: 9000 nM
Beside the measured number, compound 3's estimate is 1.2-fold (0.09 log units) above it; measured number inside the range.
By their numbers in this assay, from the lowest: compounds 1, 3 and 2 (each within the scatter of the next).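

At this saturated chain carbon bound to a saturated ring carbon, 1,2,3,4-tetrahydroisoquinolin-2-yl also leaves the number in this assay within the scatter of both earlier compounds (a 1.9-fold lower number from compound 2 to compound 3 (0.29 log units; within the scatter); a 1.0-fold higher number from compound 1 to compound 3 (0.01 log units; within the scatter)). Benzyloxy and the two ring groups at this place therefore cannot be told apart in this read-out, although they differ in size and ring type. No measured evidence bears on this result.

On these data alone, whether a carboxylic acid or a primary amine at this place would give a step beyond the scatter remains open.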